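Methyl in Place of Cyano: Expecting No Real Shift

The source may report more compounds than this note shows. Statements on the series, on what has been measured and on what is new or still open speak of the compounds shown alone.

Three compounds share one core and differ only in the group on the aromatic ring, para to a large group. Compound 3 `CC1=C(/C=C/C(=O)/C=C/c2ccc(C#N)cc2)C(C)(C)CCC1` carries a cyano group there; in a functional assay on MCF7 cells (Homo sapiens) for cytotoxicity, read by sulforhodamine B assay, with a stated time of 48 h (on this read-out lower numbers stand for stronger inhibition and higher numbers for weaker inhibition), compound 3 gives 13200 nM. Among the three measured numbers, that of compound 3 is the second highest. Compound 1 `CC1=C(/C=C/C(=O)/C=C/c2ccc(Cl)cc2)C(C)(C)CCC1` carries chloro, and in this assay compound 1 gives 10200 nM. Compound 2 `CC1=C(/C=C/C(=O)/C=C/c2ccc(Br)cc2)C(C)(C)CCC1` carries bromo, and in this assay compound 2 gives 20100 nM. The three sit close together: a 1.3-fold higher number from compound 1 to compound 3 (0.11 log units; within the scatter), a 1.5-fold lower number from compound 2 to compound 3 (0.18 log units; within the scatter), and a 2.0-fold higher number from compound 1 to compound 2 (0.29 log units; within the scatter). None of these exchanges moves the number beyond the scatter.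

Compound 4 `CC1=C(/C=C/C(=O)/C=C/c2ccc(C)cc2)C(C)(C)CCC1` is not yet measured. Its change from compound 3 is methyl in place of cyano on an aromatic carbon. Among the compounds with values here, no measured step involves a methyl group, so nothing speaks directly for this exact swap. What bears on it is that the three exchanges at this same place, among chloro, bromo and cyano, all stayed within the scatter. The expectation in this assay is therefore no step beyond the scatter, with an estimated step of a 1.0-fold lower number from compound 3 to compound 4 (0.01 log units; within the scatter). Compound 4 is expected to give about 13000 nM, with a range from 5000 nM to 35000 nM.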

Compound 4, half-maximal inhibitory concentration: 23800 nM
Estimate against measurement, compound 4: 1.8-fold (0.26 log units) below, and the stated range covers the measured number.
By their numbers in this assay, from the lowest: compounds 1, 3, 2 and 4 (each within the scatter of the next, the first and the last beyond it).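

In this assay, within the data shown here, methyl at this place on the ring produces the first step beyond the scatter in the set, though a modest one, with a 2.3-fold higher number from compound 1 to compound 4 (0.37 log units; beyond the scatter) as the swap for chloro. The other two swaps stay within the scatter, with a 1.8-fold higher number from compound 3 to compound 4 (0.26 log units; within the scatter) for cyano and a 1.2-fold higher number from compound 2 to compound 4 (0.07 log units; within the scatter) for bromo, so the methyl group, which has no hydrogen-bond acceptor where cyano has one, can be told apart only from chloro. Nothing measured here explains that single separation, which rests on one pair of compounds and lies not far beyond the scatter.

From the compounds shown here alone, all four groups are small and sit at the same place, so it remains open how this position would respond to a different kind of group, such as an amine, a carboxylic acid or a longer chain. Going by these compounds, since the four numbers lie close together, it also remains open whether any change at this place can bring a much lower number in this assay on these cells.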